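Sulfur substituent changes on the shared core

The source may hold more compounds than are shown below. What is called first, only, known or untested is meant among the compounds shown, and "the series" means these compounds.

Measured so far in a functional assay on SMMC-7721 cells (Homo sapiens) for antiproliferative activity, read by CCK-8 assay, with a stated time of 48 h; on this read-out lower numbers stand for stronger inhibition and higher numbers for weaker inhibition: compound 1 `CCSc1n[nH]c(-n2[se]c3ccccc3c2=O)n1` gives 10000 nM; compound 2 `Cc1ccc(CSc2n[nH]c(-n3[se]c4ccccc4c3=O)n2)cc1` gives > 50000 nM.

In this assay compound 2 stands only at a limit of the assay, not a number, namely > 50000 nM; the limit of > 50000 nM in this assay, at which 1 of the 2 values shown sits, marks where it sits. Compound 3 `CC(C)Sc1n[nH]c(-n2[se]c3ccccc3c2=O)n1` differs from compound 2 by isopropyl in place of 4-methylbenzyl on a sulfur. Going by the values given here, the one measured step that bears on this change is an at least 5.0-fold higher number from compound 1 to compound 2 (0.69 log units; beyond the scatter), which went in the opposite direction, toward the larger group on the sulfur. Returning to a small alkyl group, the expected step is an at least 4.1-fold lower number from compound 2 to compound 3 (0.61 log units; beyond the scatter), toward a lower number and beyond the scatter. Compound 3 is therefore estimated at 12000 nM, within a range of 4000 nM to 45000 nM.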

Compound 3, half-maximal inhibitory concentration: 6010 nM
Estimate against measurement, compound 3: 2.0-fold (0.30 log units) above; the measured number falls inside the stated range.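

Isopropyl in place of 4-methylbenzyl on a sulfur gives an at least 8.3-fold lower number from compound 2 to compound 3 (0.92 log units; beyond the scatter), so activity returns with the smaller group. Adding a methyl on the saturated chain carbon bound to the sulfur gives a 1.7-fold lower number from compound 1 to compound 3 (0.22 log units; within the scatter), so this branching does not separate the two small alkyl compounds. Compound 2 remains a limit, not a number, so the first step has only a lower bound: the limit of > 50000 nM in this assay, at which 1 of the 3 values shown sits.

Going by these compounds, it remains open whether a longer chain on the sulfur behaves like isopropyl or like 4-methylbenzyl. Also open, on these data alone, is how an amine or a carboxylic acid at the end of such a chain would read.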